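Swapping the Amide Aryl Group: Compound 3 to Compound 4

This account rests on a few compounds, and the source may have more. Where it says the series, first, only, none or still open, it means among the compounds named here.

Compound 1 `O=C(O)CCC(=O)OCCCCCCSc1ccc([N+](=O)[O-])c2nonc12`; in a functional assay on A549 cells (Homo sapiens) for inhibition, read by MTT assay, with a stated time of 72 h (a lower number here means a stronger inhibitor, a higher number a weaker inhibitor), compound 1 gives 3640 nM.
Compound 2 `O=C(CCC(=O)OCCCCCCSc1ccc([N+](=O)[O-])c2nonc12)Nc1ccccc1`; in this assay compound 2 gives 1960 nM.
Compound 3 `O=C(CCC(=O)OCCCCCCSc1ccc([N+](=O)[O-])c2nonc12)Nc1cccc(Cl)c1`; in this assay compound 3 gives 5290 nM.

Among the measured compounds shown here, compound 3 stands at the highest of the three numbers in this assay, though its gap to compound 1 is within the scatter; only the step of a 2.7-fold higher number from compound 2 to compound 3 (0.43 log units; beyond the scatter) lies beyond it. Compound 4 `COc1ccc(NC(=O)CCC(=O)OCCCCCCSc2ccc([N+](=O)[O-])c3nonc23)cc1OC` differs from compound 3 by 3,4-dimethoxyphenyl in place of 3-chlorophenyl on an amide-type nitrogen. For the measured compounds named here, no measured step exchanges one aryl substituent for another; the steps touching this end of the molecule are a 1.9-fold lower number from compound 1 to compound 2 (0.27 log units; within the scatter), a 1.5-fold higher number from compound 1 to compound 3 (0.16 log units; within the scatter) and a 2.7-fold higher number from compound 2 to compound 3 (0.43 log units; beyond the scatter), all modest. A step of similar size is therefore expected for compound 4 in this assay, more likely towards a lower number than a higher one, but not surely beyond the scatter. The estimate for compound 4 is 3500 nM (range 1500 nM to 9000 nM), an expected step of a 1.5-fold lower number from compound 3 to compound 4 (0.18 log units; within the scatter).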

Compound 4, half-maximal inhibitory concentration: 3890 nM
For compound 4 the middle estimate is 1.1-fold (0.05 log units) below the measured one; low and high end bracket the measured number.
By their numbers in this assay, from the lowest: compounds 2, 1, 4 and 3 (each within the scatter of the next, the first and the last beyond it).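

Among the compounds shown here, the first exchange of one substituted aryl group for another on this amide-type nitrogen, 3-chlorophenyl to 3,4-dimethoxyphenyl, stays within the scatter in this assay (a 1.4-fold lower number from compound 3 to compound 4 (0.13 log units; within the scatter)). The 3,4-dimethoxyphenyl group also stays within the scatter of the parent phenyl (a 2.0-fold higher number from compound 2 to compound 4 (0.30 log units; within the scatter)) and of the free acid's hydroxy (a 1.1-fold higher number from compound 1 to compound 4 (0.03 log units; within the scatter)), so this end of the molecule has so far tolerated all four groups with little change. No evidence on the cause of these steps is available.

From the compounds shown here alone, it remains open whether a pyridyl or benzyl group on this nitrogen, or a shorter chain to the shared core, would move the number beyond the scatter.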